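Swapping the nitrile on the fused core of compound 3

The source may hold more compounds than are shown below. What is called first, only, known or untested is meant among the compounds shown, and "the series" means these compounds.

Measured so far in a functional assay on CHO cells for antagonist activity at C-C chemokine receptor type 4 (Homo sapiens), read by GTPgammaS binding; on this read-out lower numbers stand for stronger inhibition and higher numbers for weaker inhibition:
- compound 1 `CC(=O)NCc1cccc(Cn2nc(NS(=O)(=O)c3ccc(Cl)s3)c3c(F)cccc32)c1` gives 79.4 nM
- compound 2 `CC(=O)NCc1cccc(Cn2nc(NS(=O)(=O)c3ccc(Cl)s3)c3c(O)cccc32)c1` gives 12.6 nM
- compound 3 `CC(=O)NCc1cccc(Cn2nc(NS(=O)(=O)c3ccc(Cl)s3)c3c(C#N)cccc32)c1` gives 316 nM

Compound 3 stands at the top of these three numbers, that is, it is the weakest inhibitor in this assay: the change from fluoro to cyano gave a 4.0-fold higher number from compound 1 to compound 3 (0.60 log units; beyond the scatter), and the change from hydroxy to cyano gave a 25-fold higher number from compound 2 to compound 3 (1.40 log units; beyond the scatter). Compound 4 `CC(=O)NCc1cccc(Cn2nc(NS(=O)(=O)c3ccc(Cl)s3)c3c(C(F)F)cccc32)c1` differs from compound 3 in one place: difluoromethyl in place of cyano on an aromatic carbon. For the measured compounds named here, no measured pair tests this exact swap, so the two steps that lead into compound 3 are the only guide. Both show that a group other than cyano at this position went with a lower number, by a modest to large margin. A difluoromethyl group is neither fluoro nor hydroxy, so the most cautious reading is a modest move downward. For compound 4 the expected step is a 3.2-fold lower number from compound 3 to compound 4 (0.50 log units; beyond the scatter), giving an estimated value of 100 nM with a range from 30 nM to 400 nM in this assay.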

Compound 4, half-maximal inhibitory concentration: 100 nM
Compound 4: the middle estimate sits on the measured number at the digits printed; low and high end bracket the measured number.
By their numbers in this assay, from the lowest: compound 2; then compounds 1 and 4 (each within the scatter of the next); then compound 3.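

In this assay the swap gives a 3.2-fold lower number from compound 3 to compound 4 (0.50 log units; beyond the scatter) even though difluoromethyl is the larger group by heavy atoms, so a bigger group at this position does not by itself push the number up. Set against fluoro, the change gives a 1.3-fold higher number from compound 1 to compound 4 (0.10 log units; within the scatter) and this lies within the scatter, so compound 1 and compound 4 cannot be told apart here. Hydroxy stays clearly ahead, with a 7.9-fold higher number from compound 2 to compound 4 (0.90 log units; beyond the scatter) marking a gap beyond the scatter, so difluoromethyl does not reach the level of compound 2.

From the compounds shown here alone, what sets hydroxy apart stays open, as does whether an amine or a methoxy group at this position would come close to it. No measurement at hand explains any of these steps.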